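The source may hold more compounds than are shown below. What is called first, only, known or untested is meant among the compounds shown, and "the series" means these compounds.

Measured compounds in an assay on CHO cells for antagonist activity at transient receptor potential cation channel subfamily V member 1 (Homo sapiens), read by FLIPR; a lower number here means a stronger inhibitor, a higher number a weaker inhibitor:
- compound 1 `CC(C(=O)NCc1ccc(C(F)(F)F)cc1N1CCCCCCC1)c1ccc(NS(C)(=O)=O)c(F)c1`: 2.8 nM
- compound 2 `CC(C(=O)NCc1ccc(C(F)(F)F)cc1OCc1ccccc1)c1ccc(NS(C)(=O)=O)c(F)c1`: 0.9 nM
- compound 3 `CC(C(=O)NCc1ccc(C(F)(F)F)cc1OCc1ccc(F)cc1)c1ccc(NS(C)(=O)=O)c(F)c1`: 0.5 nM

Compound 1 gives the highest number of the three in this assay; its nearest neighbour is compound 2, with a 3.1-fold lower number from compound 1 to compound 2 (0.49 log units; beyond the scatter), and the furthest is compound 3, with a 5.6-fold lower number from compound 1 to compound 3 (0.75 log units; beyond the scatter). Between the two benzyloxy compounds the change is a 1.8-fold lower number from compound 2 to compound 3 (0.26 log units; within the scatter).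

The next compound, compound 4 `CC(C(=O)NCc1ccc(C(F)(F)F)cc1SC1CCCC1)c1ccc(NS(C)(=O)=O)c(F)c1`, has not been measured in this assay. Against compound 1 the change is a group of 6 heavy atoms (5 carbon, 1 sulfur; one five-membered non-aromatic ring of carbon only) in place of a group of 8 heavy atoms (7 carbon, 1 nitrogen; one eight-membered non-aromatic ring with 1 hetero atom), on an aromatic carbon. The ring that leaves is the same in both measured steps from compound 1, and in each of them its replacement by an ether-linked aromatic group brought a lower number beyond the scatter. What enters here, cyclopentylsulfanyl, is neither aromatic nor an ether, so those steps bear on compound 4 only loosely. Going by the values given here, no measured pair shows a sulfur-linked group or a five-membered ring of carbon only. Compound 4 is therefore expected to land close to compound 1, the estimated step being a 1.4-fold lower number from compound 1 to compound 4 (0.15 log units; within the scatter), leaning toward a lower number but not clearly beyond the scatter. The estimate for compound 4 in this assay is 2 nM, with a range from 0.6 nM to 7 nM.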

Compound 4, inhibition constant: 0.3 nM
Compound 4: middle estimate off by 6.7-fold (0.82 log units), on the high side; the whole stated range lies above it.
By their numbers in this assay, from the lowest: compounds 4, 3 and 2 (each within the scatter of the next, the first and the last beyond it); then compound 1.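

Working notes on the series: in this assay, the aromatic carbon ortho to a large group and meta to a trifluoromethyl group accepts cyclopentylsulfanyl, a group with no aromatic ring and no ether oxygen, in place of the eight-membered ring, giving a 9.3-fold lower number from compound 1 to compound 4 (0.97 log units; beyond the scatter). A low number here therefore does not require an ether-linked aromatic group: against the unsubstituted benzyloxy group the result is a 3.0-fold lower number from compound 2 to compound 4 (0.48 log units; beyond the scatter), while against (4-fluorobenzyl)oxy it is a 1.7-fold lower number from compound 3 to compound 4 (0.22 log units; within the scatter), so compound 3 and compound 4 cannot be separated in this assay. No supporting data are available to explain these differences at this position.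

The compounds shown do not separate the contribution of the sulfur link from that of the five-membered carbon ring, a question that cyclopentyloxy or cyclopentylamino at the same carbon would address directly. On these data alone, the effect of ring size within the sulfur-linked groups also remains open, and cyclobutylsulfanyl, cyclohexylsulfanyl and phenylsulfanyl would each test it against compound 4 with a single change.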